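Swapping a benzyl group for a sulfonyl on an amine nitrogen

The source may hold more compounds than are shown below. What is called first, only, known or untested is meant among the compounds shown, and "the series" means these compounds.

Compound 1 `COc1ccc(CN2CCc3nc(-c4ccccn4)nc(N4CCN(CCN(C)C)CC4)c3C2)cc1`: "not active" (no number reported) in an assay on A549 cells with Cystic fibrosis transmembrane conductance regulator variant F508del (Homo sapiens) as the target, read by fluorescence, with a stated time of 25 min; a lower number here means a smaller maximal response, a higher number a larger maximal response
Compound 2 `COc1ccc(CN2CCc3nc(-c4ccccn4)nc(NCCCn4ccnc4)c3C2)cc1`: "not active" (no number reported) in this assay
Compound 3 `COc1ccc(CN2CCc3nc(-c4ccccn4)nc(N4CCN(CC(N)=O)CC4)c3C2)cc1`: 36.8% in this assay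

Compound 1 has no single number in this assay; the result is recorded only as "not active" (no number reported), and compound 2 shares this outcome with "not active" (no number reported). Only compound 3 reaches a measured maximal response of 36.8%. Compound 4 `CN(C)CCN1CCN(c2nc(-c3ccccn3)nc3c2CN(S(=O)(=O)c2ccccc2)CC3)CC1` is built from compound 1 by one change: phenylsulfonyl in place of 4-methoxybenzyl on an amine nitrogen in a ring. Among the measured compounds shown here, no measured pair shows what this exchange does, so the direction and size of the step in this assay are unknown; with compound 1 giving no number, a small response for compound 4 seems the more likely outcome, though a rise toward the range of compound 3 cannot be excluded. The maximal response of compound 4 in this assay is expected to be about 15%, within 0% to 40%.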

Compound 4, largest response reached (Emax), in percent of the reference or control that the assay uses: "not active" (no number reported)
For compound 4 the study gives words and no number; no gap can be computed for the estimate.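

Compound 1 and compound 4 are both recorded only in words in this assay, so no step can be read from them. What phenylsulfonyl in place of 4-methoxybenzyl does to the response stays open, and nothing shown offers an explanation.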